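Nitro to amino on two trimethoxyphenyl-bearing cores

This account rests on a few compounds, and the source may have more. Where it says the series, first, only, none or still open, it means among the compounds named here.

Measured so far:
compound 1, `COc1ccc(-n2ccnc2-c2cc(OC)c(OC)c(OC)c2)cc1[N+](=O)[O-]`: 10000 nM
compound 2, `COc1ccc(-n2ccnc2-c2cc(OC)c(OC)c(OC)c2)cc1N`: 500 nM
compound 3, `COc1ccc(OC(=O)c2cc(OC)c(OC)c(OC)c2)cc1[N+](=O)[O-]`: a limit of the assay, > 100000 nM

In a functional assay on T47D cells (Homo sapiens) for antiproliferative activity, read by MTT assay, with a stated time of 72 h (a higher number here means a weaker inhibitor, a lower number a stronger inhibitor), compound 1 gives 10000 nM and compound 2 gives 500 nM. The change amino in place of nitro on an aromatic carbon gave a 20-fold lower number from compound 1 to compound 2 (1.30 log units; beyond the scatter). For compound 3 this assay returns only a limit, > 100000 nM. Compound 3 sits at the limit of > 100000 nM in this assay, at which 1 of the 3 values shown sits. The difference between the cores of compound 1 and compound 3 is not broken down here.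

Compound 4, `COc1ccc(OC(=O)c2cc(OC)c(OC)c(OC)c2)cc1N`, is not yet measured; it differs from compound 3 by amino in place of nitro on an aromatic carbon, the same change as between compound 1 and compound 2, made twice in all. A step of an at least 3.3-fold lower number from compound 3 to compound 4 (0.52 log units; beyond the scatter) is expected, resting on a 20-fold lower number from compound 1 to compound 2 (1.30 log units; beyond the scatter), though compound 3 is only a limit, so the starting point is uncertain. For compound 4 the estimate is 30000 nM, between 6000 nM and 150000 nM.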

Compound 4, half-maximal inhibitory concentration: > 100000 nM
Compound 4: only a limit was reported (the forecaster's own chance of this, stated with the estimate: 35%); middle value at least 3.3-fold (0.52 log units) away from the limit.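

In this assay compound 3 and compound 4 both return only a limit, so the step between them cannot be read: the limit of > 100000 nM in this assay, at which 2 of the 4 values shown sit.

From the compounds shown here alone, whether amino in place of nitro lowers the number on the core of compound 3, as it does on the core of compound 1, stays open.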